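The source may hold more compounds than are shown below. What is called first, only, known or untested is meant among the compounds shown, and "the series" means these compounds.

Among the measured compounds shown here, compound 3 `COc1cccc(CNCCCNc2ccnc3cc(-c4ccc(F)cc4)ccc23)c1O` is one of three compounds measured in an ADME assay for permeability, using PAMPA, with a stated time of 30 min, at pH 7.4; on this read-out lower numbers stand for lower permeability and higher numbers for higher permeability. In this assay compound 3 gives 237 10^-6 cm/s, level with compound 2 `COc1ccc(F)cc1CNCCCNc1ccnc2cc(-c3ccc(F)cc3)ccc12`, which gives 237 10^-6 cm/s; together they stand as the lowest of the three numbers, though the gap to compound 1 `COc1cccc(CNCCCNc2ccnc3cc(Oc4ccc(Cl)cc4)ccc23)c1O` is small, as compound 1 gives 317 10^-6 cm/s. The step of a 1.3-fold lower number from compound 1 to compound 3 (0.13 log units; within the scatter) and the step of no change at the digits printed from compound 2 to compound 3 (within the scatter) both lie within the scatter, so none of the three compounds can be set apart from the others on this read-out.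

Compound 4 `COc1cccc(CNCCCNc2ccnc3cc(C4CCCCC4)ccc23)c1O` has not yet been measured. It differs from compound 3 in one place: cyclohexyl in place of 4-fluorophenyl on an aromatic carbon. For the measured compounds named here, the one measured step that touches the same position, a 1.3-fold lower number from compound 1 to compound 3 (0.13 log units; within the scatter), exchanged one group on that aromatic carbon for another without moving the number beyond the scatter, and the step of no change at the digits printed from compound 2 to compound 3 (within the scatter), at a different site, was likewise flat. Going by the values given here, no measured compound carries a non-aromatic ring at this position, so the data give no direct guide for cyclohexyl there. On the measured steps, compound 4 is expected to show a 1.0-fold higher number from compound 3 to compound 4 (0.01 log units; within the scatter), a step no larger than the scatter, in this assay. The estimate for compound 4 is 240 10^-6 cm/s, with a range from 140 10^-6 cm/s to 400 10^-6 cm/s.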

Compound 4, apparent permeability: 23 10^-6 cm/s
Beside the measured number, compound 4's estimate is 10-fold (1.02 log units) above it; the measured number lies below the stated range.
By their numbers in this assay, from the lowest: compound 4; then compounds 2, 3 and 1 (each within the scatter of the next).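

The earlier steps shown here made this aromatic carbon look indifferent to what stands on it, but compound 4 shows that it is not: in this assay cyclohexyl in place of 4-fluorophenyl gives a 10-fold lower number from compound 3 to compound 4 (1.01 log units; beyond the scatter) and cyclohexyl in place of 4-chlorophenoxy gives a 14-fold lower number from compound 1 to compound 4 (1.14 log units; beyond the scatter) with both steps large and beyond the scatter. Among the compounds shown here, the two compounds with an aromatic ring in the group at this place, compound 1 and compound 3, stay within the scatter of each other, while the one compound with a six-membered non-aromatic ring of carbon only stands well apart, even though the exchange in the step to compound 4 leaves the counts of hydrogen-bond donors, hydrogen-bond acceptors and net charge unchanged. Nothing given here accounts for the size of this drop.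

The compounds shown leave open whether a large step follows from losing the aromatic ring as such or is particular to cyclohexyl, a question that a plain phenyl, a pyridine ring, a piperidine ring or a cyclopentyl group at this place would bear on. They also leave open whether the same exchange would give a step of similar size with the 5-fluoro-2-methoxyphenyl group of compound 2 on the chain.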